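Swapping the cyano ring for a dimethyl ring

The source may report more compounds than this note shows. Statements on the series, on what has been measured and on what is new or still open speak of the compounds shown alone.

Measured so far:
compound 1 `CC(C)(C)N(NC(=O)c1ccc(I)cc1)C(=O)c1ccccc1Cl`, 7.59 nM
compound 2 `CC(C)(C)N(NC(=O)c1ccc(C#N)cc1)C(=O)c1ccccc1Cl`, 603 nM

In an assay on cells for agonist activity at ecdysone receptor (Bombyx mori), read by a luciferase reporter, with a stated time of 24 h (a lower number here means that less compound is needed, a higher number that more compound is needed for the effect), compound 2 gives the higher of the two numbers; compound 1 sits a 79-fold higher number from compound 1 to compound 2 (1.90 log units; beyond the scatter) away, a step made by putting a cyano in place of an iodo on an aromatic carbon. Compound 3 `Cc1ccc(C(=O)NN(C(=O)c2ccccc2Cl)C(C)(C)C)c(C)c1` differs from compound 2 in one place: 2,4-dimethylphenyl in place of 4-cyanophenyl on a carbonyl carbon. Among the measured compounds shown here, no measured step covers exactly this exchange, but the step from compound 1 to compound 2 shows that changing the group on this carbonyl carbon can move the result far, well beyond the scatter. Since compound 2 already stands at the high end, a change away from the cyano ring is expected to give a lower number, with wide uncertainty, so the step of a 15-fold lower number from compound 2 to compound 3 (1.18 log units; beyond the scatter) is expected. Compound 3 is therefore estimated at 40 nM, in the range 6 nM to 250 nM.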

Compound 3, half-maximal effective concentration: 162 nM
The estimate for compound 3 lay 4.1-fold (0.61 log units) below the measured number, and the stated range covers the measured number.
By their numbers in this assay, from the lowest: compound 1; then compound 3; then compound 2.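

In this assay, the 2,4-dimethylphenyl ring gives a result that is closer to the 4-cyanophenyl ring than to the 4-iodophenyl ring on the log scale: a 3.7-fold lower number from compound 2 to compound 3 (0.57 log units; beyond the scatter) is a modest step, whereas a 21-fold higher number from compound 1 to compound 3 (1.33 log units; beyond the scatter) is a large one. Losing the nitrile, with its one hydrogen-bond acceptor, therefore does not by itself bring the number down to that of compound 1, so at this position an all-carbon replacement recovers only part of the gap. No measurement is available to explain why the three rings fall in this order.

Going by these compounds, whether a single methyl group would give the same result remains open, and either of the two methyl groups could matter more. On these data alone, it is also open how a 4-bromophenyl or 4-aminophenyl ring would compare with the 4-iodophenyl ring of compound 1.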